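A few compounds are considered here, and "the series" means these few. Any claim that something is new, unique, unknown or untested is made for them only; others in the source may bear on it.

The measured compounds in a functional assay (B cells) with Mus musculus as the target; a higher number here means that more compound is needed for the effect, a lower number that less compound is needed:
compound 1 `Nc1nc(O)c2c(n1)n(C1OC(CO)[C@@H](O)[C@H]1O)c(=O)n2CC(O)CSc1ccccc1`, giving 142 uM;
compound 2 `N#Cc1ccc(Cn2c(=O)n(C3OC(CO)[C@@H](O)[C@H]3O)c3nc(N)nc(O)c32)cc1`, giving 15 uM;
compound 3 `Cn1c(=O)n(C2OC(CO)[C@@H](O)[C@H]2O)c2nc(N)nc(O)c21`, giving 10 uM.

Compound 3 has the lowest number of the three, though compound 2 sits within the scatter of it, as the step of a 1.5-fold lower number from compound 2 to compound 3 (0.18 log units; within the scatter) shows; compound 1 stands far higher, as a 14-fold lower number from compound 1 to compound 3 (1.15 log units; beyond the scatter) shows. Compound 4 `NC(=O)Cn1c(=O)n(C2OC(CO)[C@@H](O)[C@H]2O)c2nc(N)nc(O)c21` differs from compound 3 by carbamoyl in place of hydrogen on a saturated chain carbon bound to an aromatic nitrogen. Both steps that bear on this position run from a larger group to hydrogen at the same carbon: a 14-fold lower number from compound 1 to compound 3 (1.15 log units; beyond the scatter) and a 1.5-fold lower number from compound 2 to compound 3 (0.18 log units; within the scatter). Groups placed at this carbon have therefore raised the number or left it unchanged. A step of about a 1.4-fold higher number from compound 3 to compound 4 (0.15 log units; within the scatter) is expected in this assay, toward a higher number but near the scatter. Compound 4 is thus estimated at 14 uM, within the range 5 uM to 40 uM.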

Compound 4, concentration for half-maximal effect: 190 uM
The estimate for compound 4 lay 14-fold (1.13 log units) below the measured number, outside the stated range (above it).
By their numbers in this assay, from the lowest: compounds 3 and 2 (each within the scatter of the next); then compounds 1 and 4 (each within the scatter of the next).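

In this assay, carbamoyl on this saturated chain carbon bound to an aromatic nitrogen raises the number sharply (a 19-fold higher number from compound 3 to compound 4 (1.28 log units; beyond the scatter)), so a group of only 3 heavy atoms can cost as much here as a much larger one. The size of the entering group does not set the outcome: carbamoyl stands well above 4-cyanophenyl (a 13-fold higher number from compound 2 to compound 4 (1.10 log units; beyond the scatter)) but level with 1-hydroxy-2-(phenylsulfanyl)ethyl (a 1.3-fold higher number from compound 1 to compound 4 (0.13 log units; within the scatter)). No measurement shown here explains this pattern. On these data alone, whether a carboxylic acid or an amine at this carbon would behave like carbamoyl stays open, as does the effect of a longer chain carrying the carbamoyl.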